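The source may report more compounds than this note shows. Statements on the series, on what has been measured and on what is new or still open speak of the compounds shown alone.

Among the measured compounds shown here, compound 1 `COc1cc(/C=N/c2c(C#N)ncn2-c2ccc(F)cc2)cc(OC)c1OC` is one of two compounds measured in a functional assay on T47D cells (Homo sapiens) for antiproliferative activity, read by MTT assay, with a stated time of 48 h (on this read-out higher numbers stand for weaker inhibition and lower numbers for stronger inhibition), where compound 1 gives 13700 nM. Compound 2 `COc1ccc(/C=N/c2c(C#N)ncn2-c2ccc(F)cc2)cc1OC` gives 7230 nM in this assay; the gap, a 1.9-fold lower number from compound 1 to compound 2 (0.28 log units; within the scatter), leaves compound 1 with the higher of the two numbers but not separated from compound 2. Compound 3 `COc1cc(/C=N/c2c(C#N)ncn2Cc2ccc(F)cc2)cc(OC)c1OC` differs from compound 1 by 4-fluorobenzyl in place of 4-fluorophenyl on an aromatic nitrogen. For the measured compounds named here, no measured step touches this change; the one step available alters only a methoxy group and was small. Compound 3 is therefore expected to show no step beyond the scatter, an estimated 1.1-fold lower number from compound 1 to compound 3 (0.02 log units; within the scatter), giving 13000 nM with a range from 4500 nM to 40000 nM.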

Compound 3, half-maximal inhibitory concentration: 17500 nM
For compound 3 the middle estimate is 1.3-fold (0.13 log units) below the measured one; measured number inside the range.
By their numbers in this assay, from the lowest: compounds 2, 1 and 3 (each within the scatter of the next, the first and the last beyond it).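

Among the compounds shown here, the earlier compounds differed only at a methoxy group, so this is the first view of the aromatic nitrogen: in this assay, 4-fluorobenzyl in place of 4-fluorophenyl gives a 1.3-fold higher number from compound 1 to compound 3 (0.11 log units; within the scatter), a step within the scatter. At this position, the two groups therefore cannot be told apart on this read-out. No measured evidence here offers an explanation for this result. Still open, as far as these compounds go, is whether a different kind of group on this nitrogen, such as a carboxylic acid or a longer chain ending in an amine, would give a step beyond the scatter.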